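Branching the Ester Chain: From Phenethyl to 1-Phenylethyl

This account rests on a few compounds, and the source may have more. Where it says the series, first, only, none or still open, it means among the compounds named here.

Measured compounds: compound 1 `CCCOC(=O)C1=C(C)NC(C)=C(C(=O)OCC)C1c1csc(-c2ccc(Cl)cc2)n1` gives 4090 nM in an assay on isolated protein for antagonist activity at Voltage-dependent L-type calcium channel subunit alpha-1C (Cavia porcellus), with a stated time of 15 min; on this read-out lower numbers stand for stronger inhibition and higher numbers for weaker inhibition; compound 2 `CCOC(=O)C1=C(C)NC(C)=C(C(=O)OCc2ccccc2)C1c1csc(-c2ccc(Cl)cc2)n1` gives 3290 nM; compound 3 `CCOC(=O)C1=C(C)NC(C)=C(C(=O)OCCc2ccccc2)C1c1csc(-c2ccc(Cl)cc2)n1` gives 12100 nM.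

Compound 3 has the highest number of the three in this assay; the nearest, compound 1, sits at a 3.0-fold higher number from compound 1 to compound 3 (0.47 log units; beyond the scatter), and the step from compound 2 is a 3.7-fold higher number from compound 2 to compound 3 (0.57 log units; beyond the scatter). Compound 4 `CCOC(=O)C1=C(C)NC(C)=C(C(=O)OC(C)c2ccccc2)C1c1csc(-c2ccc(Cl)cc2)n1` differs from compound 3 only by 1-phenylethyl in place of phenethyl on an oxygen next to a carbonyl group. Both steps that reach compound 3 show that the phenethyl ester carries the weakest inhibition of the set, while the benzyl ester of compound 2 did not differ from compound 1 beyond the scatter. As the 1-phenylethyl group keeps its ring closer to the oxygen, as in benzyl, compound 4 is expected to move back toward the lower numbers, a step of a 2.4-fold lower number from compound 3 to compound 4 (0.38 log units; beyond the scatter). Compound 4 is therefore estimated at 5000 nM, with a range from 2000 nM to 14000 nM.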

Compound 4, half-maximal inhibitory concentration: 13800 nM
For compound 4 the middle estimate is 2.8-fold (0.44 log units) below the measured one, within the range that was stated.
By their numbers in this assay, from the lowest: compounds 2 and 1 (each within the scatter of the next); then compounds 3 and 4 (each within the scatter of the next).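

In this assay, 1-phenylethyl and phenethyl cannot be told apart on this oxygen (a 1.1-fold higher number from compound 3 to compound 4 (0.06 log units; within the scatter)), so the closer ring of 1-phenylethyl does not place compound 4 with the benzyl ester. A single methyl on the chain carbon bound to the aromatic carbon and the oxygen gives (a 4.2-fold higher number from compound 2 to compound 4 (0.62 log units; beyond the scatter)), and 1-phenylethyl in place of propyl gives (a 3.4-fold higher number from compound 1 to compound 4 (0.53 log units; beyond the scatter)). No measurement shown here accounts for this result.

The compounds shown leave open where an isopropyl ester, with its branch but no ring, or a longer chain such as 3-phenylpropyl would fall.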